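The source may hold more compounds than are shown below. What is called first, only, known or untested is meant among the compounds shown, and "the series" means these compounds.

Measured so far:
compound 1, `Clc1ccccc1-n1cc(CSc2nc3ccccc3s2)nn1`: 83.3% in a functional assay on the whole organism (strain Albino Wistar) for inhibition, with Rattus norvegicus as the target, read by paw edema, with stated times of 1 h and 3 h, at a dose of 10 mg/kg by the oral route; on this read-out higher numbers stand for more inhibition at the one dose given (going by the name of the read-out) and lower numbers for less inhibition
compound 2, `Cc1ccccc1-n1cc(CSc2nc3ccccc3s2)nn1`: 47.3% in this assay

Compound 2 stands lowest of the two numbers in this assay; its nearest neighbour is compound 1, and the step of a number 36 percentage points lower from compound 1 to compound 2 (beyond the scatter) lies beyond the scatter.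

Compound 3, `c1ccc(-n2cc(CSc3nc4ccccc4s3)nn2)cc1`, is not yet measured. It differs from compound 2 by hydrogen in place of methyl on an aromatic carbon.

For the measured compounds named here, only one measured step exists, a number 36 percentage points lower from compound 1 to compound 2 (beyond the scatter), and it concerns methyl in place of chloro, not hydrogen in place of methyl. No measured pair tracks the removal of the methyl, so the direction of the step to compound 3 is not fixed by the data; the one step shown says only that a change at this position can move the number by a large amount.

The expectation for compound 3 is a step of a number 2.7 percentage points higher from compound 2 to compound 3 (within the scatter), given as an estimate with wide limits. The estimated value for compound 3 in this assay is 50%, with a range from 25% to 75%.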

Compound 3, a percentage reported as inhibition, in the whole organism at one dose (the size of the read-out at that dose, not a potency): 46.7%
For compound 3 the middle estimate is 3.3 percentage points above the measured one, and the stated range covers the measured number.
By their numbers in this assay, from the lowest: compounds 3 and 2 (each within the scatter of the next); then compound 1.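

In this assay, hydrogen in place of methyl gives a number 0.6 percentage points lower from compound 2 to compound 3 (within the scatter), so going from 2-methylphenyl to phenyl leaves the read-out within the scatter and the methyl cannot be told apart from hydrogen on this carbon. Hydrogen in place of chloro gives a number 36.6 percentage points lower from compound 1 to compound 3 (beyond the scatter), which compares the chloro compound directly with the plain phenyl and shows that, among the three groups here, only chloro stands apart from the other two. Nothing available explains why chloro differs from methyl and hydrogen at this place.

Going by these compounds, whether the high reading is particular to chloro or also comes with bromine or fluorine on this carbon remains open. So does whether a methoxy group or an amine here would read with compound 1 or with compound 2 and compound 3.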